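Exchanging the 1-methyl-1H-pyrazol-4-yl group of compound 1

The source may report more compounds than this note shows. Statements on the series, on what has been measured and on what is new or still open speak of the compounds shown alone.

In a physicochemical assay for solubility, read by spectrophotometry, at pH 6.8 (on this read-out lower numbers stand for lower solubility and higher numbers for higher solubility), compound 1 `Cn1cc(-c2ccc(N(C(=O)NCc3ccccc3)[C@H]3CC[C@H](Nc4ccc(C#N)cn4)CC3)cc2)cn1` gives 0.33 ug/mL and stands lowest of the two numbers measured. Compound 2 `N#Cc1ccc(N[C@H]2CC[C@H](N(C(=O)NCc3ccccc3)c3ccc(-c4cccnc4)cc3)CC2)nc1` gives 0.67 ug/mL there, and that exchange amounts to a 2.0-fold higher number from compound 1 to compound 2 (0.31 log units; beyond the scatter) with a different entering group. Compound 3 `Cn1c(-c2ccc(N(C(=O)NCc3ccccc3)[C@H]3CC[C@H](Nc4ccc(C#N)cn4)CC3)cc2)cccc1=O` gives < 0.09 ug/mL as a limit of the assay, not a number. Compound 4 `Cn1ccc(-c2ccc(N(C(=O)NCc3ccccc3)[C@H]3CC[C@H](Nc4ccc(C#N)cn4)CC3)cc2)cc1=O` differs from compound 1 by a group of 8 heavy atoms (6 carbon, 1 nitrogen, 1 oxygen; one six-membered aromatic ring with 1 hetero atom) in place of a group of 6 heavy atoms (4 carbon, 2 nitrogen; one five-membered aromatic ring with 2 hetero atoms), on an aromatic carbon and remains unmeasured. For the measured compounds named here, the closest precedent is compound 3, whose entering group has the same counted make-up, and an at least 3.6-fold lower number from compound 1 to compound 3 (0.56 log units; beyond the scatter) is joined by an at least 7.4-fold lower number from compound 2 to compound 3 (0.87 log units; beyond the scatter) in the same direction. A modest drop in this assay is therefore expected, the estimated change being a 2.2-fold lower number from compound 1 to compound 4 (0.34 log units; beyond the scatter) on this reading. Compound 4 is expected at 0.15 ug/mL with an estimated range from 0.07 ug/mL to 0.45 ug/mL in this measurement.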

Compound 4, solubility: < 0.08 ug/mL
Compound 4 gave a limit, no number; the forecaster's own chance of this, stated with the estimate: 35%; at least 1.8-fold (0.27 log units) between middle value and limit.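

At this place, on an aromatic carbon para to a large group, this assay shows a second entering ring of the same counted make-up as in compound 3 also going down, with an at least 4.1-fold lower number from compound 1 to compound 4 (0.61 log units; beyond the scatter) and an at least 8.3-fold lower number from compound 2 to compound 4 (0.92 log units; beyond the scatter). The drop thus appears with both arrangements of these atoms, in compound 3 and compound 4, each a limit and not a number, and the step between those two cannot be read.

As far as these compounds go, how far either compound lies beyond its limit stays open. So does whether an amine or a carboxylic acid on the pyridin-3-yl group of compound 2 would give a higher number.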